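Swapping pyrimidine substituents on a thiourea-linked isoxazole amide

The source may hold more compounds than are shown below. What is called first, only, known or untested is meant among the compounds shown, and "the series" means these compounds.

Of the compounds shown here, three sharing one core have been measured so far. Compound 1, with structure `COc1cc(Cl)nc(NC(=S)NC(=O)c2c(-c3ccc(Cl)cc3Cl)noc2C)n1`, gives 30.7% in a functional assay on the whole organism for inhibition, with Brassica napus as the target, with a stated time of 72 h, tested at 10 mg/L; a lower number here means less inhibition of growth, a higher number more inhibition of growth at the concentration tested. Compound 2, with structure `CSc1cc(C)nc(NC(=S)NC(=O)c2c(-c3ccc(Cl)cc3Cl)noc2C)n1`, gives 42.4%, and compound 3, with structure `CSc1cc(C)nc2n/c(=N/C(=O)c3c(-c4ccc(Cl)cc4Cl)noc3C)sn12`, gives 32.8%. Compound 2 holds the highest number of the three: its gap to compound 3 lies within the scatter, while its gap to compound 1 lies beyond it, as the step of a number 11.7 percentage points higher from compound 1 to compound 2 (beyond the scatter) shows.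

Compound 4, with structure `COc1cc(OC)nc(NC(=S)NC(=O)c2c(-c3ccc(Cl)cc3Cl)noc2C)n1`, is not yet measured. It differs from compound 2 in one place: 4,6-dimethoxypyrimidin-2-yl in place of 4-methyl-6-(methylsulfanyl)pyrimidin-2-yl on an amide-type nitrogen. Going by the values given here, the only measured step touching this part of the molecule is the one from compound 1 to compound 2, where replacing a chloro and methoxy pair on the pyrimidine by a methyl and methylsulfanyl pair raised inhibition by a modest margin. Compound 4 returns to two methoxy groups, closer in kind to compound 1 than to compound 2, so a step back downward is expected, though one small enough that it may remain inside the scatter. For compound 4 the expected step is a number 8.4 percentage points lower from compound 2 to compound 4 (within the scatter). Compound 4 is therefore estimated at 34%, with a range from 18% to 50%.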

Compound 4, percent growth inhibition at one concentration: 35.2%
Compound 4: the middle estimate sits 1.2 percentage points below what was measured; low and high end bracket the measured number.
By their numbers in this assay, from the lowest: compounds 1, 3, 4 and 2 (each within the scatter of the next, the first and the last beyond it).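

In this assay, the change to 4,6-dimethoxypyrimidin-2-yl on the amide-type nitrogen gives a number 7.2 percentage points lower from compound 2 to compound 4 (within the scatter), while methoxy in place of chloro on an aromatic carbon gives a number 4.5 percentage points higher from compound 1 to compound 4 (within the scatter). Going by these compounds alone, compound 4 therefore cannot be separated from either neighbour, even though the pair it links differs by more than the scatter, so the new result adds no second clear step at this position and shows that neither of these two single changes can be read as a real shift on its own. No measured evidence is available to explain these numbers.

The compounds shown leave open whether the methyl group or the methylsulfanyl group matters more for the difference between compound 1 and compound 2, since those two groups enter together and are never separated in these structures. They also leave open how this assay would respond to a pyrimidine carrying an amino group, a trifluoromethyl group or a longer alkylsulfanyl chain in place of the groups seen so far.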